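The source may report more compounds than this note shows. Statements on the series, on what has been measured and on what is new or still open speak of the compounds shown alone.

In a functional assay on NFS-60 cells (Mus musculus) for inhibition, with a stated time of 72 h (on this read-out higher numbers stand for weaker inhibition of growth and lower numbers for stronger inhibition of growth), compound 1 `COc1ccc(Cn2nc(Br)c3c(NC(=O)c4csc5c(N)ncnc45)cccc32)cc1` gives 2390 nM and compound 2 `Nc1ncnc2c(C(=O)Nc3cccc4c3c(Br)nn4Cc3cccnc3)csc12` gives 77 nM, the lower of the two numbers. Compound 3 `Nc1ncnc2c(C(=O)Nc3cccc4c3c(Br)nn4Cc3ccncc3)csc12`, still unmeasured, differs from compound 2 by pyridin-4-yl in place of pyridin-3-yl on a saturated chain carbon bound to an aromatic nitrogen. Going by the values given here, the one measured step at this place, a 31-fold lower number from compound 1 to compound 2 (1.49 log units; beyond the scatter), is large, but it replaces 4-methoxyphenyl and does not compare the two pyridinyl groups. No direction follows from it, so no change beyond the scatter is expected in this assay. The expected step is a 1.3-fold higher number from compound 2 to compound 3 (0.11 log units; within the scatter). For compound 3 the estimated value is 100 nM, with a range of 30 nM to 350 nM.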

Compound 3, concentration for 50% growth inhibition: 135 nM
The estimate for compound 3 lay 1.4-fold (0.13 log units) below the measured number, and the stated range covers the measured number.
By their numbers in this assay, from the lowest: compounds 2 and 3 (each within the scatter of the next); then compound 1.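

In this assay, pyridin-4-yl in place of pyridin-3-yl on a saturated chain carbon bound to an aromatic nitrogen gives a 1.8-fold higher number from compound 2 to compound 3 (0.24 log units; within the scatter) and so does not separate the two pyridinyl groups. The large step away from 4-methoxyphenyl also holds for the second pyridinyl group, with an 18-fold lower number from compound 1 to compound 3 (1.25 log units; beyond the scatter) as its size. Nothing at hand accounts for either step.

As far as these compounds go, whether the step follows from the ring nitrogen or from the loss of the methoxy group remains open. Plain phenyl and pyridin-2-yl at this place would bear on that question.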